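Adding a Methyl Group: What One Earlier Pair Suggests

A few compounds are considered here, and "the series" means these few. Any claim that something is new, unique, unknown or untested is made for them only; others in the source may bear on it.

Three compounds have been run in an ADME assay on microsomes from liver (Rattus norvegicus) for metabolic stability, using NADPH; on this read-out lower numbers stand for slow clearance and higher numbers for fast clearance. Compound 1 `CC(O)CNC(=O)c1nc(Br)c(C(F)(F)F)cc1N` gives 0.0377 mL/min/kg. Compound 2 `CC(C)(O)CNC(=O)c1nc(Br)c(C(F)(F)F)cc1N` differs from compound 1 by methyl in place of hydrogen on a saturated chain carbon bound to an oxygen on a saturated carbon and two saturated chain carbons. For compound 2 the assay reports only a limit, < 0.025 mL/min/kg. That limit is the limit of < 0.025 mL/min/kg in this assay, at which 1 of the 3 values shown sits, and the step of an at least 1.5-fold lower number from compound 1 to compound 2 (0.17 log units; that floor lies within the scatter) rests on it. Compound 3 `Cc1nc(C(=O)NCC(C)(O)C(F)(F)F)c(N)cc1C(F)(F)F` gives 0.0738 mL/min/kg; the difference between the core of compound 3 and the core of compound 1 is not broken down here.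

Compound 4 `CCc1nc(C(=O)NCC(C)(O)C(F)(F)F)c(N)cc1C(F)(F)F` has not yet been measured. It differs from compound 3 by methyl in place of hydrogen on a saturated chain carbon bound to an aromatic carbon. Among the compounds with values here, this is the same kind of change as the one from compound 1 to compound 2, but the place differs: in compound 2 the new methyl sits on a saturated chain carbon bound to an oxygen on a saturated carbon and two saturated chain carbons, whereas in compound 4 it sits on a saturated chain carbon bound to an aromatic carbon. Within the data shown here, the only measured example of such a change, an at least 1.5-fold lower number from compound 1 to compound 2 (0.17 log units; that floor lies within the scatter), stayed within the scatter. On that ground compound 4 is expected to show a similarly small step, a 1.1-fold lower number from compound 3 to compound 4 (0.02 log units; within the scatter). The estimate for compound 4 in this assay is 0.07 mL/min/kg, with a likely range from 0.03 mL/min/kg to 0.16 mL/min/kg.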

Compound 4, clearance: 0.0856 mL/min/kg
The estimate for compound 4 lay 1.2-fold (0.09 log units) below the measured number; the measured number falls inside the stated range.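

In this assay, methyl in place of hydrogen on a saturated chain carbon bound to an aromatic carbon, which turns methyl into ethyl, gives a 1.2-fold higher number from compound 3 to compound 4 (0.06 log units; within the scatter), a step too small to tell apart from the ordinary spread of repeated measurements. The added methyl sits in a different place on each core, and the two steps can be compared only this far: the same change on two cores in this assay, an at least 1.5-fold lower number (0.17 log units; that floor lies within the scatter) from compound 1 to compound 2 and a 1.2-fold higher number (0.06 log units; within the scatter) from compound 3 to compound 4; the limit leaves it open whether they differ. Going by these compounds, compound 2 stands only as a limit, and the pair does not show that the change behaves alike on both cores, because the true size of the earlier step remains unknown: the limit of < 0.025 mL/min/kg in this assay, at which 1 of the 4 values shown sits.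

The compounds shown leave open what a chain longer than ethyl, such as propyl, or a cyclopropyl group would do on that same aromatic carbon. With one step on each core, they also leave open whether a methyl added at the same place on both cores would give matching results.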